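Hydroxy to methoxy on compound 3

This account rests on a few compounds, and the source may have more. Where it says the series, first, only, none or still open, it means among the compounds named here.

In a functional assay on NCI-H157 cells (Homo sapiens) for antiproliferative activity, read by sulforhodamine B assay, with a stated time of 48 h, tested at 1 uM (a lower number here means less inhibition of growth, a higher number more inhibition of growth at the concentration tested), compound 3 (`Oc1ccc(OCc2nn3c(-c4ccncc4)nnc3s2)cc1`) gives 56.3%. Compound 1 (`Cc1occc1-c1nn2c(-c3ccncc3)nnc2s1`), which gives 51.9%, lies within the usual scatter of that number, so the two stand level. Compound 2 (`Fc1ccc(OCc2nn3c(-c4ccncc4)nnc3s2)cc1`) gives 25.6% and stands clearly lower than compound 3.

Compound 4 (`COc1ccc(OCc2nn3c(-c4ccncc4)nnc3s2)cc1`) differs from compound 3 in one place: methyl in place of hydrogen on an oxygen on an aromatic ring. This puts methyl in place of hydrogen on an oxygen on an aromatic ring, turning 4-hydroxyphenyl into 4-methoxyphenyl.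

For the measured compounds named here, no measured step makes this exact change. The nearest evidence is a number 30.7 percentage points higher from compound 2 to compound 3 (beyond the scatter), a large rise beyond the scatter with hydroxy in place of fluoro on an aromatic carbon. It shows that this assay can respond strongly when the hydroxy group of compound 3 is replaced. Compound 4 keeps the oxygen but loses the hydrogen, so a partial loss seems more likely than either no change or the full drop seen with compound 2 at 25.6%. The data cannot settle this, and the direction remains an expectation resting on a single step.

The expected change is a moderate fall, estimated as a number 14.3 percentage points lower from compound 3 to compound 4 (beyond the scatter). Compound 4 is expected to give about 42%, with an estimated range of 24% to 60%.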

Compound 4, percent growth inhibition at one concentration: 61.7%
Compound 4: middle estimate off by 19.7 percentage points, on the low side, and the stated range ends below it.
By their numbers in this assay, from the lowest: compound 2; then compounds 1, 3 and 4 (each within the scatter of the next).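

In this assay, methyl in place of hydrogen on the oxygen leaves the number in place (a number 5.4 percentage points higher from compound 3 to compound 4 (within the scatter)), so within these compounds the hydrogen of the hydroxy group is not needed to hold the level of compound 3. The other comparison (a number 36.1 percentage points higher from compound 2 to compound 4 (beyond the scatter)) matches in size the large step already seen with hydroxy (a number 30.7 percentage points higher from compound 2 to compound 3 (beyond the scatter)): both groups that put an oxygen on this aromatic carbon stand clearly above fluoro, and among compounds 2, 3 and 4 nothing goes against this. Nothing available explains why hydroxy and methoxy stand level or why fluoro stands apart.

The compounds shown leave open whether an amine on that aromatic carbon would stand with compounds 3 and 4 or with compound 2, which would test whether an oxygen is needed there at all. They also leave open whether ethoxy, with a longer chain on the oxygen, would keep the level of compound 4 or whether the tolerance for methyl ends there.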